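Swapping a Ring at the Chain End in Cytotoxic Amides

This account rests on a few compounds, and the source may have more. Where it says the series, first, only, none or still open, it means among the compounds named here.

Four amides share one core and a side chain that ends in a small saturated ring holding a nitrogen. Compound 1 `COc1cc2c(Oc3ccc(NC(=O)c4nnn(-c5ccccc5C)c4C)cc3F)ccnc2cc1OCCCN1CCCC1` carries a pyrrolidin-1-yl there, and in a functional assay on MKN-45 cells (Homo sapiens) for cytotoxicity, read by MTT assay, with a stated time of 72 h (a higher number here means a weaker inhibitor, a lower number a stronger inhibitor), compound 1 gives 270 nM. Compound 3 `COc1cc2c(Oc3ccc(NC(=O)c4nnn(-c5ccccc5C)c4C)cc3F)ccnc2cc1OCCCN1CCCCC1` differs from it only by piperidin-1-yl in place of pyrrolidin-1-yl on a saturated chain carbon, three bonds along the chain from an oxygen on an aromatic ring. In this assay compound 3 gives 160 nM, so this change produced a 1.7-fold lower number from compound 1 to compound 3 (0.23 log units; within the scatter).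

Compound 2 `COc1cc2c(Oc3ccc(NC(=O)c4nnn(-c5ccc(F)cc5)c4C(F)(F)F)cc3F)ccnc2cc1OCCCN1CCCC1` differs from compound 1 in a larger part of the molecule; how the two cores differ is not broken down here. In this assay compound 2 gives 21 nM, the lowest of the three measured numbers, and its gaps to compound 3 and to compound 1 both lie beyond the scatter.

Compound 4 `COc1cc2c(Oc3ccc(NC(=O)c4nnn(-c5ccc(F)cc5)c4C(F)(F)F)cc3F)ccnc2cc1OCCCN1CCCCC1` has not yet been measured. It differs from compound 2 by piperidin-1-yl in place of pyrrolidin-1-yl on a saturated chain carbon, three bonds along the chain from an oxygen on an aromatic ring, the same change that was made between compound 1 and compound 3, now applied to the core of compound 2. Because the earlier instance of this change gave a 1.7-fold lower number from compound 1 to compound 3 (0.23 log units; within the scatter), a step of about the same small size is expected for compound 4, namely a 1.4-fold lower number from compound 2 to compound 4 (0.15 log units; within the scatter). The estimate for compound 4 in this assay is therefore 15 nM, with a range from 6 nM to 45 nM. This rests on a single measured pair, so the range is kept wide.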

Compound 4, half-maximal inhibitory concentration: 40 nM
Compound 4: the middle estimate sits 2.7-fold (0.43 log units) below what was measured; the measured number falls inside the stated range.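

In this assay, putting piperidin-1-yl in place of pyrrolidin-1-yl on the core of compound 2 gives a 1.9-fold higher number from compound 2 to compound 4 (0.28 log units; within the scatter), so each of the two steps taken alone is small, yet they do not point the same way. Set side by side, they differ by more than repeated measurements would normally explain: the same change on two cores in this assay, a 1.7-fold lower number (0.23 log units; within the scatter) from compound 1 to compound 3 and a 1.9-fold higher number (0.28 log units; within the scatter) from compound 2 to compound 4, 3.2-fold (0.51 log units) apart, beyond the scatter of two such steps

This shows that, for these two cores, the step measured on one core cannot simply be carried over as a fixed number to the other, and the outcome of the ring swap depends to some degree on the core that carries it. It does not show why the two cores part ways, nor that either ring is the better choice on either core, and one pair per core cannot establish a rule for the wider series.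

The two cores differ in more than one place, so the compounds shown leave open which of those differences matters for the ring swap. Also open, on these data alone, is how a morpholin-4-yl ring, an open-chain dimethylamino group or a chain longer than propyl at this end of the molecule would behave on each core.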